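Pyrimidinyl for trifluoromethylphenyl on the piperazine nitrogen

This account rests on a few compounds, and the source may have more. Where it says the series, first, only, none or still open, it means among the compounds named here.

Measured so far:
compound 1 `COc1cc2ncnc(N3CCC(CN4CCN(c5cccc(Cl)c5)CC4)C3)c2cc1OC`, in an assay on membranes from CHO-K1 cells for displacement of a labelled ligand from 5-hydroxytryptamine receptor 7 (Homo sapiens), read by scintillation counting; a lower number here means a stronger inhibitor, a higher number a weaker inhibitor: 372 nM
compound 2 `COc1cc2ncnc(N3CCC(CN4CCN(c5cccc(C(F)(F)F)c5)CC4)C3)c2cc1OC`, in this assay: 229 nM

Compound 2 stands at the lower of the two numbers, yet the step of a 1.6-fold lower number from compound 1 to compound 2 (0.21 log units; within the scatter) lies within the scatter, so no order between compound 1 and compound 2 follows from it.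

Compound 3 `COc1cc2ncnc(N3CCC(CN4CCN(c5ncccn5)CC4)C3)c2cc1OC` has not been measured. It differs from compound 2 in one place: pyrimidin-2-yl in place of 3-(trifluoromethyl)phenyl on an amine nitrogen in a ring. Among the compounds with values here, no measured step bears on this change. Within the data shown here, the only step known, a 1.6-fold lower number from compound 1 to compound 2 (0.21 log units; within the scatter), alters a substituent on the same aromatic ring and says nothing about exchanging the ring for a heteroaromatic one. The expectation therefore rests on the value of compound 2 alone, widened for the untested exchange.

Compound 3 is expected to give 600 nM in this assay, with a range from 150 nM to 2500 nM. The expected step is a 2.6-fold higher number from compound 2 to compound 3 (0.42 log units; beyond the scatter), a loss beyond the scatter but held with low confidence.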

Compound 3, inhibition constant: > 1000 nM
Compound 3 ended at the assay's limit; the forecaster's own chance of this, stated with the estimate: 10%; at least 1.6-fold (0.22 log units) between middle value and limit.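

In this assay compound 3 gives > 1000 nM, which is a limit of the assay and not a number: the limit of > 1000 nM in this assay, at which 1 of the 3 values shown sits.

The exchange of chloro for trifluoromethyl on the phenyl ring left no readable order, whereas exchanging the whole ring on this amine nitrogen does, with an at least 4.3-fold higher number from compound 2 to compound 3 (0.64 log units; beyond the scatter) and an at least 2.6-fold higher number from compound 1 to compound 3 (0.42 log units; beyond the scatter). At this position, then, the two substituted phenyl compounds stand apart from the pyrimidin-2-yl compound, and the nature of the ring counts for more in this series than the choice between those two substituents.

From the compounds shown here alone, the limit bounds the loss on one side only, so its full size stays open. The compounds shown do not separate the ring nitrogens from the lost substituent, a question that unsubstituted phenyl, pyridin-2-yl or a trifluoromethyl-bearing pyrimidin-2-yl would address.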